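The source may report more compounds than this note shows. Statements on the series, on what has been measured and on what is new or still open speak of the compounds shown alone.

Measured compounds:
compound 1, `CCc1cccc(Nc2cc(NC(=O)Nc3cc(OC)cc(OC)c3)ncn2)c1`: 36.7%
compound 2, `COc1cc(NC(=O)Nc2cc(Nc3cc(C)cc(F)c3)ncn2)cc(OC)c1`: 35.3%
compound 3, `COc1cc(NC(=O)Nc2cc(Nc3ccc(Br)cc3OC)ncn2)cc(OC)c1`: 25.7%

All three share one core and differ only in the aryl group on a nitrogen on an aromatic ring. In a functional assay on NCI-H226 cells (Homo sapiens) for inhibition, read by MTT assay, with a stated time of 48 h, tested at 10 uM (a higher number here means more inhibition at the concentration tested (going by the name of the read-out), a lower number less inhibition), compound 3 sits at the low end of the set: the step of a number 11 percentage points lower from compound 1 to compound 3 (beyond the scatter) lies beyond the scatter, whereas the step of a number 9.6 percentage points lower from compound 2 to compound 3 (within the scatter) lies within it, so compound 2 and compound 3 cannot be ranked against each other. The step of a number 1.4 percentage points lower from compound 1 to compound 2 (within the scatter) is also within the scatter.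

Compound 4, `COc1cc(NC(=O)Nc2cc(Nc3ccc(C(C)(C)C)cc3)ncn2)cc(OC)c1`, continues this series with 4-(tert-butyl)phenyl in place of 4-bromo-2-methoxyphenyl on a nitrogen on an aromatic ring. Within the data shown here, every measured step concerns the same aryl group, and the largest of them was only modest; the 4-(tert-butyl)phenyl group, however, has no measured counterpart here, so its effect is uncertain. The expected outcome is a small shift, most likely back toward the values of compound 1 and compound 2, without confidence that it exceeds the scatter. Compound 4 is expected to give 32%, within a range from 18% to 46%. This estimate corresponds to an expected step of a number 6.3 percentage points higher from compound 3 to compound 4 (within the scatter).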

Compound 4, a percentage reported as inhibition, at one concentration (the size of the read-out at that concentration, not a potency): 47.7%
Beside the measured number, compound 4's estimate is 15.7 percentage points below it; measured number outside the range, above it.
By their numbers in this assay, from the lowest: compounds 3, 2 and 1 (each within the scatter of the next, the first and the last beyond it); then compound 4.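

In this assay, the 4-(tert-butyl)phenyl group sets compound 4 apart from all three earlier compounds, with steps of a number 22 percentage points higher from compound 3 to compound 4 (beyond the scatter), a number 12.4 percentage points higher from compound 2 to compound 4 (beyond the scatter) and a number 11 percentage points higher from compound 1 to compound 4 (beyond the scatter), which gives compound 4 the highest number of the four. The earlier compounds shown here had separated only compound 1 from compound 3, whereas this result shows that a change at this position can also lift inhibition clear of the group formed by compound 1 and compound 2. No measurement shown here explains the gain.

Going by these compounds, whether the tert-butyl group itself matters remains open, as the aryl groups differ in more than one feature. On these data alone, it is also open how the position would respond to an amine, a carboxylic acid or a longer alkyl chain on the aryl group.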